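The source may report more compounds than this note shows. Statements on the series, on what has been measured and on what is new or still open speak of the compounds shown alone.

Compound 1 `C=C(c1cccc2ccccc12)C1CCC2(CC1)COC(Nc1ccc(OC)cc1)OO2`: 5.46
Compound 2 `C=C(c1cccc2ccccc12)C1CCC2(CC1)COC(Nc1ccccc1-c1ccccc1)OO2`: 7.26
Compound 3 `C=C(c1cccc2ccccc12)C1CCC2(CC1)COC(Nc1cccc(C(F)(F)F)c1)OO2`: 6.51

These readings come from a physicochemical assay for lipophilicity; on this read-out higher numbers stand for higher lipophilicity and lower numbers for lower lipophilicity. Compound 2 stands highest of the three at 7.26. Compound 3 is nearest, with a number 0.75 log units lower from compound 2 to compound 3 (beyond the scatter), and compound 1 lies furthest down.

Compound 4 `C=C(c1ccc2ccccc2c1)C1CCC2(CC1)COC(Nc1ccccc1-c1ccccc1)OO2` has not yet been measured. It departs from compound 2 in one place: naphthalen-2-yl in place of naphthalen-1-yl on a double-bonded chain carbon bound to a saturated ring carbon. Naphthalen-2-yl stands in place of naphthalen-1-yl on a double-bonded chain carbon bound to a saturated ring carbon, so the two have the same atoms, joined differently.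

The measured steps all concern the group on an amine nitrogen. Two are large, a number 1.80 log units higher from compound 1 to compound 2 (beyond the scatter) and a number 1.05 log units higher from compound 1 to compound 3 (beyond the scatter), and one is modest, a number 0.75 log units lower from compound 2 to compound 3 (beyond the scatter). Each replaces one group with another of different make-up, and none touches the naphthalen-1-yl group, so they offer no direct measure of this change. They show only how far this assay moved when the group on that nitrogen was replaced.

With the atoms unchanged, no step beyond the scatter is expected, and compound 2 at 7.26 serves as the anchor. The expected change is a number 0.04 log units higher from compound 2 to compound 4 (within the scatter). Compound 4 is estimated at 7.3, with an expected range of 6.9 to 7.7.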

Compound 4, partition coefficient: 7.26
The estimate for compound 4 lay 0.04 log units above the measured number; the measured number falls inside the stated range.
By their numbers in this assay, from the lowest: compound 1; then compound 3; then compounds 2 and 4 (each within the scatter of the next).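

In this assay, putting naphthalen-2-yl in place of naphthalen-1-yl on a double-bonded chain carbon bound to a saturated ring carbon gives no change at the digits printed from compound 2 to compound 4 (within the scatter). Among the compounds shown here, this is the first reading of a change at this position, as the earlier steps all concerned the group on an amine nitrogen: with 2-phenylphenyl on that nitrogen, joining the same atoms differently leaves the read-out where it was. No measurement at hand offers an explanation for why the two naphthalene attachments read alike.

The compounds shown leave open whether the same match would hold with 4-methoxyphenyl or 3-(trifluoromethyl)phenyl on the amine nitrogen, since naphthalen-2-yl appears here only alongside 2-phenylphenyl. They also leave open how far the read-out would move if a different kind of group stood on that double-bonded chain carbon, such as a smaller phenyl ring, a nitrogen-containing quinolinyl group or a saturated cyclohexyl ring, rather than one of the two naphthalene attachments.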